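The compounds below may be only part of what the source reports. "The series", "measured", "known", "first", "only" and "open" are said of these compounds alone.

Working notes on the series. The shared core carries a hydrazone linked to a nitrophenyl group and an acylhydrazone whose aroyl part is varied. Compound 1 `CC(/C=N/Nc1ccc([N+](=O)[O-])cc1)=N\NC(=O)c1ccc([N+](=O)[O-])cc1` is the reference; in a functional assay on cells (Splenocyte, Mus musculus, strain BALB/c) for inhibition, read by scintillation counting and thymidine incorporation, with a stated time of 72 h (a lower number here means a stronger inhibitor, a higher number a weaker inhibitor), compound 1 gives 980 nM. Compound 2 `CC(/C=N/Nc1ccc([N+](=O)[O-])cc1)=N\NC(=O)c1ccccc1N` gives 4900 nM, a step of a 5.0-fold higher number from compound 1 to compound 2 (0.70 log units; beyond the scatter). Compound 3 `CC(/C=N/Nc1ccc([N+](=O)[O-])cc1)=N\NC(=O)c1ccccc1Cl` sits at the limit of the assay rather than at a number: compound 3 gives > 12000 nM. Going by the values given here, that is the only value in the set at the limit, (the limit of > 12000 nM in this assay, at which 1 of the 3 values shown sits). The steps onto compound 3 are an at least 12-fold higher number from compound 1 to compound 3 (1.08 log units; beyond the scatter) and an at least 2.4-fold higher number from compound 2 to compound 3 (0.38 log units; beyond the scatter); both run toward weaker inhibition.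

The next compound, compound 4 `CC(/C=N/Nc1ccc([N+](=O)[O-])cc1)=N\NC(=O)c1cccc(C)c1`, changes the aroyl part once more: 3-methylphenyl in place of 2-chlorophenyl on a carbonyl carbon. Among the compounds with values here, no measured step touches a 3-methylphenyl, so the steps above bear only indirectly. Two aroyl variations away from compound 1 both lost activity, and the largest loss came with compound 3, which is the starting point here. Without a step that speaks for methyl, the working expectation for compound 4 is an inhibitor staying close to the limit region, so the step is estimated as a step that the limit leaves unreadable from compound 3 to compound 4. For compound 4 the estimate is 15000 nM, within 4000 nM to 60000 nM, with a substantial chance that the assay again reports only a limit.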

Compound 4, half-maximal inhibitory concentration: > 12000 nM
Compound 4: only a limit was reported (the forecaster's own chance of this, stated with the estimate: 55%); the middle value lies beyond the limit too.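

In this assay compound 4 gives > 12000 nM, which is a limit of the assay and not a number, and it is the second such value in the set: the limit of > 12000 nM in this assay, at which 2 of the 4 values shown sit.

The result gives an at least 12-fold higher number from compound 1 to compound 4 (1.08 log units; beyond the scatter) and an at least 2.4-fold higher number from compound 2 to compound 4 (0.38 log units; beyond the scatter), so the loss at this position is not confined to 2-chlorophenyl: a 3-methylphenyl on the same carbonyl carbon, with carbon as its only heavy atom, also ends at the limit of this assay. The step between compound 3 and compound 4 cannot be read, since both values are limits, and the two groups cannot be ranked against each other.

On these data alone, how far compound 3 and compound 4 lie beyond the limit stays open, and so does whether the 2-chlorophenyl and 3-methylphenyl groups differ at all in this read-out. Also open, as far as these compounds go, is whether an aroyl part carrying a nitrile or a carboxylic acid would stay near compound 1 or lose activity as well.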